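Notes on Oxetan-3-yl Removal at the Piperazine Nitrogen

This account rests on a few compounds, and the source may have more. Where it says the series, first, only, none or still open, it means among the compounds named here.

compound 1, `c1cnc2c(c1)CCC[C@@H]2N(CC1CC1)C[C@H]1Cc2c(cccc2N2CCNCC2)CN1`: 26.7 nM
compound 2, `Cc1cnc2c(c1)CCC[C@@H]2N(C)C[C@H]1Cc2c(cccc2N2CCNCC2)CN1`: 16.1 nM
compound 3, `CN(C[C@H]1Cc2c(cccc2N2CCN(C3COC3)CC2)CN1)[C@H]1CCCc2cccnc21`: 381 nM

All three compounds were run in a functional assay on CCRF-CEM cells for antagonist activity at C-X-C chemokine receptor type 4 (Homo sapiens), read by calcium flux, with stated times of 25 min and 90 s; on this read-out lower numbers stand for stronger inhibition and higher numbers for weaker inhibition. Compound 3 gives the highest number of the three; the gap to compound 1 and the gap to compound 2 both lie beyond the usual scatter of repeated measurements, so compound 3 is the weakest inhibitor of the set as it stands.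

Compound 4, `CN(C[C@H]1Cc2c(cccc2N2CCNCC2)CN1)[C@H]1CCCc2cccnc21`, has not yet been measured in this assay. It differs from compound 3 in a single place: hydrogen in place of oxetan-3-yl on an amine nitrogen in a ring. The unsubstituted piperazin-1-yl of compound 4 is the same ring as that carried by compound 1 and compound 2, and the rest of compound 4 matches compound 3.

The expectation for compound 4 is a clear drop in the number, a step of a 13-fold lower number from compound 3 to compound 4 (1.10 log units; beyond the scatter) in this assay, well beyond the scatter, because compound 1 gives 26.7 nM and compound 2 gives 16.1 nM with the same bare piperazin-1-yl. The estimate for compound 4 in this assay is 30 nM, with a range from 12 nM to 80 nM.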

Compound 4, half-maximal inhibitory concentration: 6.08 nM
The estimate for compound 4 lay 4.9-fold (0.69 log units) above the measured number; the measured number lies below the stated range.
By their numbers in this assay, from the lowest: compound 4; then compounds 2 and 1 (each within the scatter of the next); then compound 3.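

In this assay the piperazine nitrogen now has a direct comparison with the rest of the molecule held constant: hydrogen in place of oxetan-3-yl on this ring nitrogen gives a 63-fold lower number from compound 3 to compound 4 (1.80 log units; beyond the scatter), a large step that places the weak result of compound 3 on the oxetan-3-yl itself. Compound 4 also connects the two earlier bare piperazin-1-yl compounds, with a 2.6-fold lower number from compound 2 to compound 4 (0.42 log units; beyond the scatter) for hydrogen in place of methyl on an aromatic carbon and a 4.4-fold lower number from compound 1 to compound 4 (0.64 log units; beyond the scatter) for hydrogen in place of cyclopropyl on a saturated chain carbon bound to an amine nitrogen, both modest steps that leave compound 4 as the strongest inhibitor of the four. Nothing on hand gives a reason for the size of any of these steps.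

Going by these compounds, with only hydrogen and oxetan-3-yl seen on this nitrogen, it remains open whether an ethyl group, an acetyl group or a longer chain carrying a carboxylic acid would fall near compound 4 or near compound 3. On these data alone, whether oxetan-3-yl carries a similar penalty on compound 1 or compound 2 also remains open.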